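Phenyl for butyl on the aryl ether oxygen

The compounds below may be only part of what the source reports. "The series", "measured", "known", "first", "only" and "open" are said of these compounds alone.

Working notes on the series. Going by the values given here, in a functional assay on Hypothalamus for inhibition of Norepinephrine transporter (Rattus norvegicus) (a higher number here means a weaker inhibitor, a lower number a stronger inhibitor), compound 2 `CCCCOc1ccc([C@@H]2CC[C@H](NC)c3ccccc32)cc1` gives 940 nM, the lowest of the two numbers measured so far; compound 1 `CN[C@@H]1CC[C@@H](c2ccc(Oc3ccccc3)cc2)c2ccccc21` gives 2300 nM in this assay, a gap beyond the usual scatter. Among the compounds with values here, no pair differing in a single place has been measured, so the size of the step to compound 3 `CN[C@H]1CC[C@@H](c2ccc(Oc3ccccc3)cc2)c2ccccc21` rests on expectation alone. The change is phenyl in place of butyl on an oxygen on an aromatic ring. A modest rise in this assay, toward a weaker inhibitor, is expected, with the step from compound 2 to compound 3 estimated at a 1.6-fold higher number from compound 2 to compound 3 (0.20 log units; within the scatter). Compound 3 is estimated at 1500 nM, within 500 nM to 4500 nM.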

Compound 3, half-maximal inhibitory concentration: 3900 nM
Compound 3: the middle estimate sits 2.6-fold (0.41 log units) below what was measured; measured number inside the range.
By their numbers in this assay, from the lowest: compound 2; then compounds 1 and 3 (each within the scatter of the next).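

In this assay, phenyl in place of butyl on an oxygen on an aromatic ring gives a 4.1-fold higher number from compound 2 to compound 3 (0.62 log units; beyond the scatter), the first single-place step measured in the series. Configuration at the saturated ring carbon gives a 1.7-fold higher number from compound 1 to compound 3 (0.23 log units; within the scatter), so that stereocentre does not separate this pair beyond the scatter. This pair isolates that one stereocentre: the fact that compounds 1 and 3 differ only in the configuration as drawn

The compounds shown leave open whether a cyclohexyl group on the same oxygen would follow phenyl or butyl. Also open, going by these compounds, is how a shorter chain such as methyl would read there, and whether the butoxy compound responds to the same change of configuration.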